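A few compounds are considered here, and "the series" means these few. Any claim that something is new, unique, unknown or untested is made for them only; others in the source may bear on it.

Of the compounds shown here, three have been tested in an ADME assay on cells for inhibition of cytochrome P450 11B1, mitochondrial (Homo sapiens), read by HTRF; a lower number here means a stronger inhibitor, a higher number a weaker inhibitor. Compound 1 `CCC(=O)N[C@@H]1CCCc2c1cncc2N1C(=O)c2ccc(Cl)cc2[C@@H]1C` gives 414 nM, compound 2 `CCC1c2cc(Cl)ccc2C(=O)N1c1cccnc1` gives 3340 nM, and compound 3 `CS(=O)(=O)N[C@@H]1CCCc2c1cncc2N1CCc2cc(Cl)ccc2C1=O` gives 5150 nM. Of these three numbers, compound 2 has the second highest; its number and that of compound 3 lie within the usual scatter of each other, while compound 1 gives a clearly lower number, beyond the scatter. Compound 4 `CC1c2cc(Cl)ccc2C(=O)N1c1cccnc1` has not yet been measured. It differs from compound 2 in one place: hydrogen in place of methyl on a saturated chain carbon bound to a saturated ring carbon, which cut one bond further out reads ethyl to methyl. For the measured compounds named here, no measured pair shows this change, so the step from compound 2 is expected to be small, likely no further than the scatter in either direction. Compound 4 is therefore estimated at 4500 nM, with a range from 1500 nM to 13000 nM, meaning an expected step of a 1.3-fold higher number from compound 2 to compound 4 (0.13 log units; within the scatter).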

Compound 4, half-maximal inhibitory concentration: 1250 nM
Compound 4: the middle estimate sits 3.6-fold (0.56 log units) above what was measured, and the stated range ends above it.
By their numbers in this assay, from the lowest: compound 1; then compound 4; then compounds 2 and 3 (each within the scatter of the next).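

In this assay, for the compounds shown here, the change from ethyl to methyl on the saturated ring carbon gives a 2.7-fold lower number from compound 2 to compound 4 (0.43 log units; beyond the scatter), the first direct reading of this position. Removing one carbon from this chain is therefore enough to give a stronger inhibitor, although this rests on a single pair of compounds. Nothing shown here accounts for the step.

Going by these compounds, whether a still shorter or a longer group continues this direction remains open. Hydrogen alone on that ring carbon, a propyl chain or an amine on the chain could each answer this.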